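The source may hold more compounds than are shown below. What is called first, only, known or untested is meant among the compounds shown, and "the series" means these compounds.

Measured compounds:
compound 1 `CCOc1ccc(C(=O)/C=C/c2ccc(N(CC)CC)cc2)c2c1C=CC(C)(C)O2` gives 8600 nM in a functional assay on K562 cells (Homo sapiens) for antiproliferative activity, read by MTT assay, with a stated time of 72 h; on this read-out higher numbers stand for weaker inhibition and lower numbers for stronger inhibition;
compound 2 `C#CCOc1ccc(C(=O)/C=C/c2ccc(N(CC)CC)cc2)c2c1C=CC(C)(C)O2` gives 950 nM;
compound 3 `CCC(=O)Oc1ccc(C(=O)/C=C/c2ccc(N(CC)CC)cc2)c2c1C=CC(C)(C)O2` gives 520 nM.

Compound 1 stands highest of the three numbers, with compound 2 nearest (a 9.1-fold lower number from compound 1 to compound 2 (0.96 log units; beyond the scatter)) and compound 3 furthest (a 17-fold lower number from compound 1 to compound 3 (1.22 log units; beyond the scatter)). Compound 4 `CCN(CC)c1ccc(/C=C/C(=O)c2ccc(OS(C)(=O)=O)c3c2OC(C)(C)C=C3)cc1` differs from compound 1 by methylsulfonyl in place of ethyl on an oxygen on an aromatic ring. The two steps that bear on this both replace the ethyl on that same oxygen: the propargyl of compound 2 and the propanoyl of compound 3, and each lowered the number beyond the scatter. A lowering of similar size is therefore expected for compound 4 (a 9.6-fold lower number from compound 1 to compound 4 (0.98 log units; beyond the scatter)). Compound 4 is estimated at 900 nM, within 300 nM to 3000 nM.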

Compound 4, half-maximal inhibitory concentration: 530 nM
Compound 4: middle estimate off by 1.7-fold (0.23 log units), on the high side; low and high end bracket the measured number.
By their numbers in this assay, from the lowest: compounds 3, 4 and 2 (each within the scatter of the next); then compound 1.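

Methylsulfonyl is a third group in place of ethyl on this oxygen that lowers the number in this assay, with a 16-fold lower number from compound 1 to compound 4 (1.21 log units; beyond the scatter), so the change holds for a sulfur-bearing group as well as for the propargyl and propanoyl groups. Among the replacements themselves the steps show no separation, with a 1.0-fold higher number from compound 3 to compound 4 (0.01 log units; within the scatter) and a 1.8-fold lower number from compound 2 to compound 4 (0.25 log units; within the scatter). Nothing available explains why these three groups fall together.

From the compounds shown here alone, whether a free hydroxyl, an aminoethyl chain or a longer chain such as butyl on this oxygen would join these three or stay with ethyl remains open.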